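Cytotoxicity notes on two measured compounds and one pending

The source may report more compounds than this note shows. Statements on the series, on what has been measured and on what is new or still open speak of the compounds shown alone.

compound 1 `O=[N+]([O-])c1cc(CSc2nnc(C3CCCCC3)n2Cc2ccccc2)cc(C(F)(F)F)c1` — > 30000 nM
compound 2 `CCCCCCCCSc1nnc(-c2cc([N+](=O)[O-])cc([N+](=O)[O-])c2)n1Cc1ccccc1` — > 30000 nM

Both measured compounds were run in an ADME assay on HepG2 cells (Homo sapiens) for cytotoxicity, with a stated time of 48 h; on this read-out higher numbers stand for weaker inhibition and lower numbers for stronger inhibition. Compound 1 `O=[N+]([O-])c1cc(CSc2nnc(C3CCCCC3)n2Cc2ccccc2)cc(C(F)(F)F)c1` gives > 30000 nM in this assay, which is a limit of the assay and not a number. Compound 2 `CCCCCCCCSc1nnc(-c2cc([N+](=O)[O-])cc([N+](=O)[O-])c2)n1Cc1ccccc1` gives > 30000 nM in this assay, again a limit rather than a number. Compound 2 thus stands at the limit of > 30000 nM in this assay, at which 2 of the 2 values shown sit. Among the compounds with values here, with both readings limits, the two values show no difference that can be read, and no pair of measured compounds differs in a single place, so no step size is known from the data.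

Compound 3 `O=[N+]([O-])c1cc(-c2nnc(SCc3ccc(Cl)cc3)n2Cc2ccccc2)cc([N+](=O)[O-])c1` differs from compound 2 by 4-chlorophenyl in place of heptyl on a saturated chain carbon bound to a sulfur. For this assay the expected step is a step that the limit leaves unreadable from compound 2 to compound 3, none beyond the scatter. Compound 3 is estimated to give 40000 nM, within a range from 12000 nM to 120000 nM, most likely reported as a limit again.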

Compound 3, half-maximal inhibitory concentration: > 30000 nM
Compound 3 was reported as a limit (the forecaster's own chance of this, stated with the estimate: 75%); the middle value lies beyond the limit too.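

Compound 2 and compound 3 both sit at a limit of the assay, so no step between them can be read: the limit of > 30000 nM in this assay, at which 3 of the 3 values shown sit.

Left open is whether any change on the shared core gives a number rather than a limit, and how large any such step would be.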